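This account rests on a few compounds, and the source may have more. Where it says the series, first, only, none or still open, it means among the compounds named here.

Working notes on the series. Of the compounds shown here, three share one core and have been tested in a functional assay on MIA PaCa-2 cells (Homo sapiens) for inhibition, read by MTT assay, with a stated time of 7 days; a lower number here means a stronger inhibitor, a higher number a weaker inhibitor. Compound 1 `CCC(CC)S(=O)(=O)c1ccc(S(=O)(=O)N2CCC[C@@H](C(=O)N3CCC(F)(F)CC3)C2)cc1` gives 13 nM. Compound 2 `CCN(CC)S(=O)(=O)c1ccc(S(=O)(=O)N2CCC[C@@H](C(=O)N3CCC(OC)CC3)C2)cc1` gives 140 nM. Compound 3 `CCN(CC)C(=O)c1ccc(S(=O)(=O)N2CCC[C@@H](C(=O)N3CCC(F)(F)CC3)C2)cc1` gives 70 nM. Within the data shown here, the one single-point step measured so far is a 5.4-fold higher number from compound 1 to compound 3 (0.73 log units; beyond the scatter). On these numbers compound 2 stands highest of the three: its gap to compound 3 lies within the scatter, its gap to compound 1 lies beyond it.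

Compound 4 `CCN(CC)S(=O)(=O)c1ccc(S(=O)(=O)N2CCC[C@@H](C(=O)N3CCC(C(F)(F)F)CC3)C2)cc1` has not been measured in this assay. It differs from compound 2 by trifluoromethyl in place of methoxy on a saturated ring carbon, that is, 4-methoxypiperidin-1-yl becomes 4-(trifluoromethyl)piperidin-1-yl. Among the measured compounds shown here, no measured step touches this place: the only step known concerns the aromatic side and not the saturated ring. For the measured compounds named here, compounds 1 and 3 each carry a different group on that saturated ring carbon from compound 2, but each also differs from compound 2 on the aromatic side, so their values show only that the two compounds lacking the methoxy sit at or below the number of compound 2. Compound 4 is therefore expected near the range spanned by compounds 2 and 3, and the step of a 1.8-fold lower number from compound 2 to compound 4 (0.24 log units; within the scatter) is an estimate carrying wide uncertainty. The estimate for compound 4 in this assay is 80 nM, with a range of 20 nM to 300 nM.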

Compound 4, half-maximal inhibitory concentration: 320 nM
Estimate against measurement, compound 4: 4.0-fold (0.60 log units) below, and the stated range ends below it.
By their numbers in this assay, from the lowest: compound 1; then compounds 3 and 2 (each within the scatter of the next); then compound 4.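

In this assay, the saturated ring carbon three ring bonds from the ring nitrogen now has a single-point step of its own: a 2.3-fold higher number from compound 2 to compound 4 (0.36 log units; beyond the scatter), with the aromatic side held fixed. This shows that the number responds to the group at this position, and that replacing methoxy with trifluoromethyl here gives a modest rise beyond the scatter, something compounds 1 and 3 could not show, each differing from compound 2 on the aromatic side as well. The data shown offer no measured basis for explaining this rise.

The compounds shown leave open how a hydroxyl, a nitrile or a primary amine on this ring carbon would compare with methoxy and trifluoromethyl on the same aromatic side. Also open, as far as these compounds go, is whether the step keeps its direction and size with the diethylcarbamoyl of compound 3 or the (pentan-3-yl)sulfonyl of compound 1 on the aromatic side.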